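The compounds below may be only part of what the source reports. "The series", "measured", "known", "first", "only" and "open" are said of these compounds alone.

Measured so far:
Compound 1, `Cc1ccc(Oc2cccc(CN3CCC(n4cc(C)c(=O)[nH]c4=O)CC3)c2)cc1`: in an ADME assay on MRC5 cells (Homo sapiens) for cytotoxicity, read by fluorescence and resazurin assay, with a stated time of 3 days (a lower number here means a stronger inhibitor, a higher number a weaker inhibitor), compound 1 gives > 64000 nM, which is a limit of the assay rather than a number.
Compound 2, `Cc1cn(C2CCN(Cc3cncc(Oc4cc(Cl)cc(Cl)c4)c3)CC2)c(=O)[nH]c1=O`: in this assay compound 2 gives > 64000 nM, again a limit.
Compound 3, `Cc1cn(C2CCN(Cc3ccnc(Oc4ccccc4)c3)CC2)c(=O)[nH]c1=O`: in this assay compound 3 gives > 64000 nM, also a limit.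

Compound 1 therefore stands only at a limit in this assay, with no number of its own, and the two other measured compounds rest at the same point: the limit of > 64000 nM in this assay, at which 3 of the 3 values shown sit. For the measured compounds named here, no two of these three compounds differ from each other in a single place, so there is no measured step whose size could guide the next one.

Compound 4, `Cc1cn(C2CCN(Cc3cccc(Oc4cccc(OC(F)(F)F)c4)c3)CC2)c(=O)[nH]c1=O`, is the compound still to be tested. It differs from compound 1 in one spot: 3-(trifluoromethoxy)phenyl in place of 4-methylphenyl on an oxygen on an aromatic ring. Going by the values given here, with no measured step in hand, and with all three known values sitting at the limit, the expectation is for no step beyond the usual scatter, and most likely for another limit rather than a number. The expected step from compound 1 to compound 4 in this assay is a step that the limit leaves unreadable from compound 1 to compound 4. For compound 4 the estimated value in this assay is 80000 nM, expected to fall between 30000 nM and 300000 nM.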

Compound 4, half-maximal inhibitory concentration: 5260 nM
Estimate against measurement, compound 4: 15-fold (1.18 log units) above, and the stated range ends above it.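

The aryl group on this oxygen turns out not to be a silent position for the cells: putting 3-(trifluoromethoxy)phenyl in place of 4-methylphenyl gives, in this assay, an at least 12-fold lower number from compound 1 to compound 4 (1.08 log units; beyond the scatter), a step that is itself a bound, since one of its ends is a limit of the assay. Compound 4 gives 5260 nM, so the series now has a real number to work from, and this single change on the core of compound 1 is enough to bring the compound inside the range the assay can read. Every other compound shown rests at one point, which gave no hint of such a step: the limit of > 64000 nM in this assay, at which 3 of the 4 values shown sit.

As far as these compounds go, what remains open is whether the trifluoromethoxy group itself or its place on the ring produces the step, as the two groups differ in both and a 3-methylphenyl or a 4-(trifluoromethoxy)phenyl on the same oxygen would be needed to separate the two. From the compounds shown here alone, it is equally open how a ring carrying a carboxylic acid or an amine would read in this assay.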